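Second Trifluoromethyl on the Urea Aryl Ring

This account rests on a few compounds, and the source may have more. Where it says the series, first, only, none or still open, it means among the compounds named here.

Measured compounds:
Compound 1 `O=C(Nc1cccc(-n2cc(-c3ccncc3)c(-c3ccc(Cl)c(O)c3)n2)c1)Nc1cccc(C(F)(F)F)c1`: 3830 nM
Compound 2 `O=C(Nc1cccc(-n2cc(-c3ccncc3)c(-c3ccc(Cl)c(O)c3)n2)c1)Nc1ccc(Cl)c(Cl)c1`: 1460 nM

In a functional assay on SW-620 cells (Homo sapiens) for inhibition, read by sulforhodamine B assay, with a stated time of 48 h (a lower number here means a stronger inhibitor of growth, a higher number a weaker inhibitor of growth), compound 1 gives 3830 nM, the higher of the two numbers at hand, and compound 2 gives 1460 nM. For the measured compounds named here, the one measured step, a 2.6-fold lower number from compound 1 to compound 2 (0.42 log units; beyond the scatter), exchanges the whole aryl group on the urea nitrogen and shows that changes at this end of the shared core can move this assay beyond the scatter. Compound 3 `O=C(Nc1cccc(-n2cc(-c3ccncc3)c(-c3ccc(Cl)c(O)c3)n2)c1)Nc1cc(C(F)(F)F)cc(C(F)(F)F)c1` differs from compound 1 by trifluoromethyl in place of hydrogen on an aromatic carbon. Going by the values given here, no measured pair adds a substituent to an aryl ring that is otherwise kept, so the step from compound 1 to compound 2 bears on it only loosely. A modest lower number is expected, a 1.5-fold lower number from compound 1 to compound 3 (0.19 log units; within the scatter). Compound 3 is therefore estimated to give about 2500 nM in this assay, with a range from 800 nM to 8000 nM.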

Compound 3, concentration for 50% growth inhibition: 1300 nM
Beside the measured number, compound 3's estimate is 1.9-fold (0.28 log units) above it; low and high end bracket the measured number.
By their numbers in this assay, from the lowest: compounds 3 and 2 (each within the scatter of the next); then compound 1.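

In this assay, the step, a 2.9-fold lower number from compound 1 to compound 3 (0.47 log units; beyond the scatter), is the first shown in which a group is added to an aryl ring that is otherwise kept. It shows that a second trifluoromethyl on an aromatic carbon, meta to a trifluoromethyl group, is enough to move the number beyond the scatter, whereas the earlier step exchanged the whole aryl group and could not isolate one substituent. Nothing available on these compounds accounts for this change.

The compounds shown leave open whether a methyl group, a chlorine atom, an amine or a carboxylic acid at this same place would lower the number as well. They also leave open how trifluoromethyl at this place would fare on a urea aryl ring without the first trifluoromethyl group.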